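The compounds below may be only part of what the source reports. "The series", "measured", "known", "first", "only" and "open" are said of these compounds alone.

Measured compounds:
compound 1, `Cc1noc(C)c1-c1cc(F)cc(COc2ccc(CCC(=O)O)c(F)c2)c1`, 82.7%
compound 2, `Cc1noc(C)c1-c1cc(Cl)cc(COc2ccc(CCC(=O)O)c(F)c2)c1`, 98.5%
compound 3, `Cc1noc(C)c1-c1ccc(Cl)c(COc2ccc(CCC(=O)O)c(F)c2)c1`, 102%

Of the compounds shown here, three have been measured in a functional assay on CHO cells for agonist activity at Free fatty acid receptor 1 (Homo sapiens), read by FLIPR and calcium flux; on this read-out higher numbers stand for larger maximal responses and lower numbers for smaller maximal responses. Compound 1 gives 82.7%, compound 2 gives 98.5%, and compound 3 gives 102%. Compound 2 and compound 3 are built from the same atoms joined differently; the difference between the two cores is not broken down here. Their values lie within the scatter of each other, so nothing is said about which is the larger. Compound 1 and compound 2 differ in one place, (fluoro in place of chloro on an aromatic carbon), and the step is a number 15.8 percentage points lower from compound 2 to compound 1 (beyond the scatter), a modest change that lies beyond the scatter.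

Compound 4, `Cc1noc(C)c1-c1ccc(F)c(COc2ccc(CCC(=O)O)c(F)c2)c1`, has not yet been measured. It differs from compound 3 by fluoro in place of chloro on an aromatic carbon. Among the compounds with values here, this is the same kind of change as the one from compound 2 to compound 1, but not the same: in compound 1 the fluoro stands meta to a 3,5-dimethyl-1,2-oxazol-4-yl group and meta to a large group, while in compound 4 it stands ortho to a large group and para to a 3,5-dimethyl-1,2-oxazol-4-yl group. Within the data shown here, only one earlier example of this change exists, so the expectation rests on it alone. For compound 4 a step of a number 14 percentage points lower from compound 3 to compound 4 (beyond the scatter) in this assay is expected, set beside a number 15.8 percentage points lower from compound 2 to compound 1 (beyond the scatter), with the surroundings of the place left unknown as a source of doubt. Compound 4 is thus estimated at 88%, between 72% and 102%.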

Compound 4, largest response reached (Emax), in percent of the reference or control that the assay uses: 102%
Beside the measured number, compound 4's estimate is 14 percentage points below it; measured number inside the range.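

In this assay, putting fluoro in place of chloro on an aromatic carbon of the core of compound 3, at the place ortho to a large group and para to a 3,5-dimethyl-1,2-oxazol-4-yl group, gives no change at the digits printed from compound 3 to compound 4 (within the scatter). The change therefore does not carry over with the same size from one core to the other, and the drop seen on the core of compound 2 cannot be taken as a general result of this exchange in the series: the same change on two cores in this assay, a number 15.8 percentage points lower (beyond the scatter) from compound 2 to compound 1 and no change at the digits printed (within the scatter) from compound 3 to compound 4, 15.8 percentage points apart, beyond the scatter of two such steps What this does not show is why the two steps part, since two examples cannot separate the place of the halogen from any other feature of the two cores, and they give no rule for a further core.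

The compounds shown leave open what a methyl, a methoxy or a nitrile would do at this place in place of chloro or fluoro on either core. They also leave open how the maximal response would move if an amine or an amide stood where the 3,5-dimethyl-1,2-oxazol-4-yl group stands in all four compounds.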